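The source may report more compounds than this note shows. Statements on the series, on what has been measured and on what is new or still open speak of the compounds shown alone.

Measured compounds in the series:
compound 1 `NS(=O)(=O)c1ccc(/N=C2\NC(=O)/C(=C3/C(=O)Nc4ccc(Br)cc43)S2)cc1` — 11300 nM
compound 2 `NS(=O)(=O)c1ccc(/N=C2\NC(=O)/C(=C3/C(=O)N(Cc4ccccc4)c4ccccc43)S2)cc1` — > 200000 nM
compound 3 `CN1C(=O)/C(=C2\S/C(=N/c3ccc(S(N)(=O)=O)cc3)NC2=O)c2ccccc21` — 51900 nM

In a functional assay on MCF7 cells (Homo sapiens) for antiproliferative activity, read by MTT assay (on this read-out higher numbers stand for weaker inhibition and lower numbers for stronger inhibition), compound 1 gives 11300 nM. Compound 3 gives 51900 nM in this assay. Within the data shown here, for compound 2 this assay reports only a limit, > 200000 nM, so its position is known only as a boundary, not as a number; it is the one value at the limit of > 200000 nM in this assay, at which 1 of the 3 values shown sits.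

The only measured step among these three is an at least 3.8-fold lower number from compound 2 to compound 3 (0.58 log units; beyond the scatter), which concerns the substituent on the amide-type nitrogen, not the aromatic ring. Compound 4 `NS(=O)(=O)c1ccc(/N=C2\NC(=O)/C(=C3/C(=O)N(Cc4ccccc4)c4ccc(Br)cc43)S2)cc1` differs from compound 2 by bromo in place of hydrogen on an aromatic carbon. Among the measured compounds shown here, no measured step isolates a bromo for hydrogen exchange on that ring: compound 1 carries the bromo but also hydrogen where compound 2 carries phenyl on the chain carbon, so its value cannot be read as a step for bromo alone. With compound 2 itself at a limit, a bromo change is expected to give no step beyond the scatter, a number no higher from compound 2 to compound 4 (the limit leaves the size open), and compound 4 is expected to sit again at or near the boundary, estimated at 200000 nM with a range from 50000 nM to 600000 nM.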

Compound 4, half-maximal inhibitory concentration: > 200000 nM
Compound 4: a limit, no number (the forecaster's own chance of this, stated with the estimate: 70%); the middle value sits exactly at the limit.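

In this assay compound 4 gives > 200000 nM, which is a limit and not a number. The step for bromo in place of hydrogen on the aromatic carbon cannot be read, as compound 2 and compound 4 are both limits. With the bromo present on both sides, benzyl in place of hydrogen on the amide-type nitrogen gives an at least 17-fold higher number from compound 1 to compound 4 (1.24 log units; beyond the scatter), so the bromo does not bring the benzyl compound back to a measurable value in this assay.

Still open, as far as these compounds go, is whether another group on that nitrogen, such as ethyl or a chain ending in an amine, keeps a measurable value with the bromo in place. From the compounds shown here alone, the size of any bromo effect on the ring also stays open, and chloro or methoxy on the same aromatic carbon remains unplaced.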